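Methoxy in place of chloro: compound 3 to compound 4

This account rests on a few compounds, and the source may have more. Where it says the series, first, only, none or still open, it means among the compounds named here.

The series is tested in a functional assay on MCF7 cells (Homo sapiens) for antiproliferative activity, read by MTT assay, with a stated time of 48 h; a higher number here means a weaker inhibitor, a lower number a stronger inhibitor. Compound 1 `N#CC1=C(N)Oc2c(c3nc4ccccc4nc3c3ccccc23)C12C(=O)N(Cc1cnnn1-c1ccc(S(N)(=O)=O)cc1)c1ccccc12` reaches only the limit of this assay, > 50000 nM. Compound 2 `Cc1ccc(-n2nncc2CN2C(=O)C3(C(C#N)=C(N)Oc4c3c3nc5ccccc5nc3c3ccccc43)c3ccccc32)cc1Cl` likewise gives a limit, > 50000 nM. The step between them, a step that the two limits leave unreadable from compound 1 to compound 2, cannot be sized: both its ends are limits. Compound 3 `N#CC1=C(N)Oc2c(N)cc3nc4ccccc4nc3c2C12C(=O)N(Cc1cnnn1-c1ccc(Cl)cc1)c1ccccc12` also stands at a limit, > 50000 nM. Its place among the numbers shown is therefore no more than this: every measured compound of the series sits at the same limit (the limit of > 50000 nM in this assay, at which 3 of the 3 values shown sit), and none is separated from another.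

Compound 4 `COc1ccc(-n2nncc2CN2C(=O)C3(C(C#N)=C(N)Oc4c(N)cc5nc6ccccc6nc5c43)c3ccccc32)cc1` differs from compound 3 by methoxy in place of chloro on an aromatic carbon. Among the measured compounds shown here, no measured step touches this place on the ring; the only measured step, from compound 1 to compound 2, changes the group on the aromatic nitrogen and is itself unreadable. Not a single step in this assay has been sized, so neither direction nor magnitude for the change from compound 3 to compound 4 can be read from the data. Compound 4 is expected to remain at the limit as well, the estimated step being a step that the limit leaves unreadable from compound 3 to compound 4. Compound 4 is estimated at 60000 nM, with a range from 20000 nM to 200000 nM.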

Compound 4, half-maximal inhibitory concentration: > 50000 nM
Compound 4: no number, only a limit (the forecaster's own chance of this, stated with the estimate: 85%); the middle value lies beyond the limit too.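

Compound 3 and compound 4 both stand only at a limit in this assay, so no new step can be read, and methoxy in place of chloro remains unsized. The compounds shown leave open whether any change on the shared core separates one compound from another, because all of them sit at one limit: the limit of > 50000 nM in this assay, at which 4 of the 4 values shown sit.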